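Methoxy in Place of Trifluoromethyl on the Ester Arm

This account rests on a few compounds, and the source may have more. Where it says the series, first, only, none or still open, it means among the compounds named here.

Of the compounds shown here, three have been measured so far in a functional assay on MCF7 cells (Homo sapiens) for antiproliferative activity, read by sulforhodamine B assay, with a stated time of 48 h, tested at 50 uM; on this read-out higher numbers stand for more inhibition at the one concentration tested (going by the name of the read-out) and lower numbers for less inhibition. Compound 1 `CC1=CC[C@H](C(C)C)c2cc(C)c(OC(=O)c3ccc(C)cc3)cc21` gives 65%. Compound 2 `Cc1cc2c(C(C)C)ccc(C)c2cc1OC(=O)c1cccc(C(F)(F)F)c1` gives 41.5%, and compound 3 `Cc1cc2c(C(C)C)ccc(C)c2cc1OC(=O)c1ccc(C(F)(F)F)cc1` gives 16.8%. Compound 2 thus stands second of the three numbers: the nearest, that of compound 1, lies higher by a margin beyond the usual scatter, and the furthest, that of compound 3, lies lower, also beyond the scatter. No two of these measured compounds differ in only one place, so no single structural change can yet be tied to a shift in the read-out.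

Compound 4 `COc1cccc(C(=O)Oc2cc3c(C)ccc(C(C)C)c3cc2C)c1` has not been measured. It differs from compound 2 in one spot: methoxy in place of trifluoromethyl on an aromatic carbon. The rest of the molecule is the same. Among the measured compounds shown here, no measured pair shows this particular swap, so its effect on the read-out is unknown from the data in hand. The step from compound 2 to compound 4 in this assay is expected to be small, a number 3.5 percentage points higher from compound 2 to compound 4 (within the scatter), and not clearly beyond the scatter in either direction. Compound 4 is therefore estimated at 45%, with a range from 20% to 70%.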

Compound 4, a percentage reported as inhibition, at one concentration (the size of the read-out at that concentration, not a potency): 31.8%
Beside the measured number, compound 4's estimate is 13.2 percentage points above it, and the stated range covers the measured number.
By their numbers in this assay, from the lowest: compound 3; then compounds 4 and 2 (each within the scatter of the next); then compound 1.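

With compound 4, this assay gains its first pair of compounds that differ in only one place, and methoxy in place of trifluoromethyl on this aromatic carbon reads as a number 9.7 percentage points lower from compound 2 to compound 4 (within the scatter), so this pair cannot be told apart from the ordinary spread of repeated measurements. For this one position on the shared core, then, two quite different groups leave the read-out without a change that can be claimed, although a single pair offers only one observation and sets no rule for other groups or other positions. Nothing at hand gives a measured basis for explaining this outcome.

On these data alone, whether an amine, a carboxylic acid or a longer chain such as ethoxy on this same aromatic carbon would also stay within the scatter of compound 2 remains open, as does the reading with a plain hydrogen there. As far as these compounds go, it is also open whether methoxy in place of trifluoromethyl would give a similar small step on the core of compound 1, or on any other ring position of the ester arm.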